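A Nitrile Enters the Seven-Membered Ring of Compound 2

A few compounds are considered here, and "the series" means these few. Any claim that something is new, unique, unknown or untested is made for them only; others in the source may bear on it.

Of the compounds shown here, three with a shared core have been measured: compound 1 `Cc1nn(C)c2c1C(c1ccccc1)=NCCN2`, compound 2 `Cc1nn(C)c2c1C(c1ccccc1Cl)=NCCN2` and compound 3 `Cc1nn(C)c2c1C(c1ccccc1Cl)=NCCN2C`. In a functional assay on the whole organism for positive allosteric modulation, with Rattus norvegicus as the target (on this read-out higher numbers stand for an effect only at larger amounts of compound and lower numbers for an effect already at smaller amounts), compound 1 gives 2.5 mg/kg. In this assay compound 2 gives 2.5 mg/kg, and compound 3 gives 2.5 mg/kg. The two steps that join them, no change at the digits printed from compound 1 to compound 2 (within the scatter) and no change at the digits printed from compound 2 to compound 3 (within the scatter), both stay within the scatter, so compound 2 stands level with compound 1 and with compound 3 on the numbers shown.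

Compound 4 `Cc1nn(C)c2c1C(c1ccccc1Cl)=NCC(C#N)N2` differs from compound 2 by a single change: cyano in place of hydrogen on a saturated ring carbon. Neither measured step bears closely on this change. The step from compound 1 to compound 2 swaps a hydrogen on an aromatic carbon for chloro, and the step from compound 2 to compound 3 puts a methyl on a ring nitrogen; neither alters a saturated ring carbon, and neither moved the read-out beyond the scatter. For the measured compounds named here, no measured pair shows a cyano entering anywhere on the core. Given that every change so far has left the dose unmoved, the expected step from compound 2 to compound 4 is no change at the digits printed from compound 2 to compound 4 (within the scatter), that is, none beyond the scatter, though with wider uncertainty than the measured steps carry. Compound 4 is therefore estimated at 2.5 mg/kg, with a range from 1 mg/kg to 6.3 mg/kg.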

Compound 4, minimum effective dose: > 10 mg/kg
Compound 4 was reported as a limit; the forecaster's own chance of this, stated with the estimate: 10%; middle value at least 4.0-fold (0.60 log units) from the limit.
By their numbers in this assay, from the lowest: compounds 1, 2 and 3 (each within the scatter of the next). At a limit, above all of these: compound 4.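

In this assay, the saturated ring carbon of the seven-membered ring is the first place among these compounds where a single change moves the read-out beyond the scatter: cyano in place of hydrogen there gives an at least 4.0-fold higher number from compound 2 to compound 4 (0.60 log units; beyond the scatter). Chloro on an aromatic carbon and methyl on the ring nitrogen had both left the minimum effective dose within the scatter; the level numbers of compounds 1, 2 and 3 therefore do not extend to this carbon, where the change shifts the effect to larger amounts of compound. The value of compound 4 is a limit of the assay and not a number: the limit of > 10 mg/kg in this assay, at which 1 of the 4 values shown sits.

The compounds shown do not tell whether the shift belongs to cyano itself or would follow any group on this carbon, such as a methyl, a hydroxyl, an amine or a carboxylic acid. Nor do they tell whether cyano on this carbon would give the same result on compound 1, with hydrogen in place of chloro, or on compound 3, with the methyl on the ring nitrogen.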